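This account rests on a few compounds, and the source may have more. Where it says the series, first, only, none or still open, it means among the compounds named here.

Three compounds share one core and differ only at the edges. Compound 1 `O=C(O)COC(=O)N(C1CC1)[C@H]1c2ccccc2N(C(=O)c2cccc(F)c2)[C@H]2CC[C@H]21` gives 13 nM in a functional assay for antagonist activity at prostaglandin D2 receptor 2 (Homo sapiens), read by flow cytometry, with stated times of 10 min and 4 min; on this read-out lower numbers stand for stronger inhibition and higher numbers for weaker inhibition. Compound 2 `O=C(O)CCC(=O)N(C1CC1)[C@H]1c2ccccc2N(C(=O)c2ccc(F)cc2)[C@H]2CC[C@H]21` gives 8.9 nM, and compound 3 `O=C(O)CCC(=O)N(C1CC1)[C@H]1c2ccccc2N(C(=O)c2cccc(F)c2)[C@H]2CC[C@H]21` gives 14 nM; all three numbers lie within the usual scatter of one another, so compound 1 stands level with both. The change to compound 4 `O=C(O)COC(=O)N(C1CC1)[C@H]1c2ccccc2N(C(=O)c2ccc(OC(F)(F)F)cc2)[C@H]2CC[C@H]21` is 4-(trifluoromethoxy)phenyl in place of 3-fluorophenyl on a carbonyl carbon. Going by the values given here, two measured steps bear on it: swapping the fluorine position on the aryl ring gave a 1.6-fold higher number from compound 2 to compound 3 (0.20 log units; within the scatter), and changing the acid-bearing chain gave a 1.1-fold higher number from compound 1 to compound 3 (0.03 log units; within the scatter). Among the compounds with values here, no measured step introduces a trifluoromethoxy group, so the expectation rests on the small size of the aryl change seen. Compound 4 is therefore estimated at 13 nM, range 5 nM to 35 nM, a step of no change at the digits printed from compound 1 to compound 4 (within the scatter) expected to stay within the scatter.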

Compound 4, half-maximal inhibitory concentration: 8.2 nM
The estimate for compound 4 lay 1.6-fold (0.20 log units) above the measured number; the measured number falls inside the stated range.
By their numbers in this assay, from the lowest: compounds 4, 2, 1 and 3 (each within the scatter of the next).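

The earlier compounds shown here only moved a fluorine on the aryl ring, whereas here 4-(trifluoromethoxy)phenyl, with 11 heavy atoms and an oxygen, replaces 3-fluorophenyl, with 7 heavy atoms, on the same carbonyl carbon. In this assay this exchange gives a 1.6-fold lower number from compound 1 to compound 4 (0.20 log units; within the scatter) and so stays within the scatter, which shows that this position accepts a substantially bigger group with no real shift in the number. Nothing available explains this result.

From the compounds shown here alone, it remains open whether the 2-carboxyethyl chain of compound 3 would give the same result with this new aryl group. Going by these compounds, an amine or a carboxylic acid on the aryl ring also remains untested here.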